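A few compounds are considered here, and "the series" means these few. Any claim that something is new, unique, unknown or untested is made for them only; others in the source may bear on it.

Measured compounds:
- compound 1, `COc1ccc(S(=O)(=O)N2CCc3cccc(-c4ccc(F)cc4)c32)cc1`, 95.5 nM in a functional assay on NCI-H460 cells (Homo sapiens) for inhibition, with a stated time of 72 h; a lower number here means a stronger inhibitor, a higher number a weaker inhibitor
- compound 2, `COc1ccc(S(=O)(=O)N2CCc3cccc(-c4ccc(F)c(F)c4)c32)cc1`, 46 nM
- compound 3, `COc1ccc(S(=O)(=O)N2CCc3cccc(-c4cccs4)c32)cc1`, 229 nM

Among these three numbers compound 1 stands second highest: compound 2 lies nearest, with a 2.1-fold lower number from compound 1 to compound 2 (0.32 log units; beyond the scatter), and compound 3 lies furthest, with a 2.4-fold higher number from compound 1 to compound 3 (0.38 log units; beyond the scatter). Between the other two the gap is a 5.0-fold higher number from compound 2 to compound 3 (0.70 log units; beyond the scatter).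

Compound 4, `COc1ccc(S(=O)(=O)N2CCc3cccc(-c4cccc(F)c4)c32)cc1`, has not yet been measured in this assay. It differs from compound 1 by 3-fluorophenyl in place of 4-fluorophenyl on an aromatic carbon.

For the measured compounds named here, no measured step moves the fluorine within the phenyl ring, so the closest guide is the step from compound 1 to compound 2, where a fluoro in place of hydrogen, giving 3,4-difluorophenyl, brought a modest lowering. The step from compound 1 to compound 3, replacing the whole ring by thiophen-2-yl, raised the number modestly and says only that the phenyl itself matters. A 3-fluorophenyl keeps that phenyl and carries its fluorine where compound 2 also carries one, so compound 4 is expected to land close to compound 1, with a step of a 1.1-fold lower number from compound 1 to compound 4 (0.05 log units; within the scatter) that is not expected to clear the scatter. The estimate for compound 4 is 85 nM, between 35 nM and 210 nM.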

Compound 4, half-maximal inhibitory concentration: 167 nM
The estimate for compound 4 lay 2.0-fold (0.29 log units) below the measured number; the measured number falls inside the stated range.
By their numbers in this assay, from the lowest: compound 2; then compounds 1, 4 and 3 (each within the scatter of the next, the first and the last beyond it).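

Moving the single fluorine, from the 4-fluorophenyl of compound 1 to the 3-fluorophenyl of compound 4, keeps the same atoms and gives a 1.7-fold higher number from compound 1 to compound 4 (0.24 log units; within the scatter) in this assay, and the exchange of the thiophen-2-yl for this ring gives a 1.4-fold lower number from compound 3 to compound 4 (0.14 log units; within the scatter), so neither the place of one fluorine nor this exchange of rings is resolved from the scatter. The one step from compound 4 that clears the scatter adds a second fluorine to the ring: read in the listed direction, it is a 3.6-fold higher number from compound 2 to compound 4 (0.56 log units; beyond the scatter), with hydrogen in place of fluoro, and it shows that the 3,4-difluorophenyl of compound 2 stands apart from the 3-fluorophenyl as well as from the 4-fluorophenyl, with compound 2 the lowest of the four numbers. Nothing given here accounts for these differences.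

The compounds shown leave open how a plain phenyl ring would compare, as every phenyl here carries fluorine. They also leave open whether a chlorine, a methoxy group or an amine on this ring would match the result of compound 2, or whether that result is particular to the two fluorines.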